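The compounds below may be only part of what the source reports. "The series", "measured", "known", "first", "only" and "open" are said of these compounds alone.

Series notes, amine substituent on the fused five-membered ring.

Compound 1 `CC(C)c1nc(C(=O)NC[C@@H]2[C@H]3CN(CC4CCC4)C[C@@H]23)c2ccccn12`: 13.2 nM
Compound 2 `CC(C)c1nc(C(=O)NC[C@@H]2[C@H]3CN(C4CCC4)C[C@@H]23)c2ccccn12`: 18 nM
Compound 3 `CC(C)c1nc(C(=O)NC[C@@H]2[C@H]3CN(C4CCOCC4)C[C@@H]23)c2ccccn12`: 20.7 nM

In a functional assay on CHO cells for agonist activity at 5-hydroxytryptamine receptor 4 (Homo sapiens), read by a luciferase reporter and cAMP accumulation, with a stated time of 4 h (a lower number here means that less compound is needed, a higher number that more compound is needed for the effect), compound 3 gives 20.7 nM, the highest of the three numbers, but the gaps to the others are small: a 1.2-fold higher number from compound 2 to compound 3 (0.06 log units; within the scatter) and a 1.6-fold higher number from compound 1 to compound 3 (0.20 log units; within the scatter), both within the scatter, as is a 1.4-fold higher number from compound 1 to compound 2 (0.13 log units; within the scatter). The three substituents on the ring nitrogen have so far made no difference that the assay can resolve.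

Compound 4 `COC(=O)N1CCC(N2C[C@@H]3[C@@H](CNC(=O)c4nc(C(C)C)n5ccccc45)[C@@H]3C2)CC1` differs from compound 3 by 1-(methoxycarbonyl)piperidin-4-yl in place of oxan-4-yl on an amine nitrogen in a ring. The same position was varied in each measured step, and none of them moved the number beyond the scatter. The incoming group is larger than any tried so far, so a small shift upward is expected, but nothing more is supported. For compound 4 the expected value in this assay is 25 nM, range 10 nM to 70 nM, meaning an expected step of a 1.2-fold higher number from compound 3 to compound 4 (0.08 log units; within the scatter).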

Compound 4, half-maximal effective concentration: 9.7 nM
The estimate for compound 4 lay 2.6-fold (0.41 log units) above the measured number; the measured number lies below the stated range.
By their numbers in this assay, from the lowest: compounds 4, 1, 2 and 3 (each within the scatter of the next, the first and the last beyond it).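

In this assay, for the compounds shown here, 1-(methoxycarbonyl)piperidin-4-yl on the amine nitrogen gives the first step at this position beyond the scatter, a 2.1-fold lower number from compound 3 to compound 4 (0.33 log units; beyond the scatter), though a modest one. Against the other two substituents it stays within the scatter, with a 1.9-fold lower number from compound 2 to compound 4 (0.27 log units; within the scatter) and a 1.4-fold lower number from compound 1 to compound 4 (0.13 log units; within the scatter), so this larger group is tolerated here with no rise in the number. Nothing measured here accounts for the step. Still open, on these data alone, is whether the methoxycarbonyl group or the piperidine ring carries the step: a piperidin-4-yl with a free ring amine, or an acetyl in place of the methoxycarbonyl, would separate the two.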